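Predicting Compound 4 from a Ring Swap Seen Once Before

This account rests on a few compounds, and the source may have more. Where it says the series, first, only, none or still open, it means among the compounds named here.

Four compounds built around an aryl urea are compared here: compound 1 `CC(NC(=O)CCc1ccc(NC(=O)Nc2ccc(Cl)c(C(F)(F)F)c2)cc1)c1ccccc1`, compound 2 `CC(NC(=O)c1ccc(-c2ccc(NC(=O)Nc3cc(C(F)(F)F)ccc3Cl)cc2)cc1)c1ccccc1`, compound 3 `CC1CN(C(=O)CCc2ccc(NC(=O)Nc3ccc(Cl)c(C(F)(F)F)c3)cc2)CC(C)O1` and the as yet unmeasured compound 4 `CC1CN(C(=O)c2ccc(-c3ccc(NC(=O)Nc4cc(C(F)(F)F)ccc4Cl)cc3)cc2)CC(C)O1`. The difference between the core of compound 1 and the core of compound 2 is not broken down here.

In a functional assay on HepG2 cells (Homo sapiens) for inhibition, read by MTT assay, with a stated time of 120 h (on this read-out higher numbers stand for weaker inhibition and lower numbers for stronger inhibition), compound 2 gives 18400 nM. For compound 1 this assay reports only a limit, > 50000 nM, and not a number. For compound 3 this assay likewise reports only a limit, > 50000 nM. Compound 3 arises from compound 1 through (2,6-dimethylmorpholin-4-yl in place of (1-phenylethyl)amino on a carbonyl carbon). The step this made is a step that the two limits leave unreadable from compound 1 to compound 3, because both values sit at the limit of > 50000 nM in this assay, at which 2 of the 3 values shown sit.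

Compound 4 arises from compound 2 through (2,6-dimethylmorpholin-4-yl in place of (1-phenylethyl)amino on a carbonyl carbon). This is the same kind of change, not the same change: in compound 1 the carbonyl carbon's other neighbour is a saturated chain carbon, whereas in compound 2 it is an aromatic carbon. Among the measured compounds shown here, the one earlier example of this swap therefore gives no readable size, and two of the three values known so far are limits rather than numbers. On that basis compound 4 is expected to stay weak, with an estimated step of a 1.9-fold higher number from compound 2 to compound 4 (0.28 log units; within the scatter) in this assay. The estimate for compound 4 is 35000 nM, with a range from 12000 nM to 100000 nM, and a fair chance that this assay again reports only a limit.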

Compound 4, half-maximal inhibitory concentration: > 50000 nM
Compound 4 ended at the assay's limit (the forecaster's own chance of this, stated with the estimate: 45%); at least 1.4-fold (0.15 log units) between middle value and limit.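

In this assay, putting 2,6-dimethylmorpholin-4-yl in place of (1-phenylethyl)amino on a carbonyl carbon whose other neighbour is an aromatic carbon gives an at least 2.7-fold higher number from compound 2 to compound 4 (0.43 log units; beyond the scatter), so on this core the swap clearly weakens inhibition. Compound 4 gives > 50000 nM, which is a limit and not a number, so this step has a smallest size but no full size. The same swap on the core of compound 1, from compound 1 to compound 3, cannot be read, so the series does not show whether the change carries over from one core to the other with a similar size, because both compounds of that pair stand at the same limit: the limit of > 50000 nM in this assay, at which 3 of the 4 values shown sit.

The swap removes an aromatic ring and a hydrogen-bond donor and brings in a non-aromatic ring with an oxygen, and the compounds shown do not separate these changes from one another. Also open, on these data alone, is whether a plain morpholin-4-yl without the two methyl groups, or a carboxylic acid, on that same carbonyl carbon would give a readable number on the core of compound 2 or would end at the limit as well.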